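The source may report more compounds than this note shows. Statements on the series, on what has been measured and on what is new or still open speak of the compounds shown alone.

Working notes on the series. Compound 3 `Cn1cnc2c1c(=O)n(CC(=O)OC(C)(C)C)c(=O)n2C` gives 17.2% in a functional assay on MGC-803 cells (Homo sapiens) for inhibition, read by MTT assay, with a stated time of 48 h, tested at 20 uM (on this read-out lower numbers stand for less inhibition and higher numbers for more inhibition at the one concentration tested (going by the name of the read-out)), and this is the lowest of the three numbers in hand. For the measured compounds named here, compound 1 `CCCn1c(SCc2ccc(F)cc2)nc2c1c(=O)[nH]c(=O)n2C` gives 86.5% in this assay and compound 2 `CCCn1c(SCc2cccc(C)c2)nc2c1c(=O)[nH]c(=O)n2C` gives 84.1% there; both sit far above compound 3, but both differ from it in several places at once, so no single step joins them to it. Going by the values given here, the one step between measured compounds, a number 2.4 percentage points lower from compound 1 to compound 2 (within the scatter), concerns a group on a saturated chain carbon bound to a sulfur and does not touch the site changed here.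

Compound 4 `Cn1cnc2c1c(=O)n(CC(=O)N1CCC(F)(F)CC1)c(=O)n2C` differs from compound 3 by 4,4-difluoropiperidin-1-yl in place of tert-butoxy on a carbonyl carbon. Among the compounds with values here, no measured pair shows what exchanging tert-butoxy for 4,4-difluoropiperidin-1-yl on this carbonyl carbon does, so the expectation rests on the starting point alone. Because compound 3 gives 17.2%, compound 4 is expected to stay near that low level, with a step of about a number 4.8 percentage points higher from compound 3 to compound 4 (within the scatter) and no change beyond the scatter. Compound 4 is therefore estimated at 22% in this assay, within a range of 5% to 45%.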

Compound 4, a percentage reported as inhibition, at one concentration (the size of the read-out at that concentration, not a potency): 11.3%
The estimate for compound 4 lay 10.7 percentage points above the measured number; measured number inside the range.
By their numbers in this assay, from the lowest: compounds 4 and 3 (each within the scatter of the next); then compounds 2 and 1 (each within the scatter of the next).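

At this position, on a carbonyl carbon whose other neighbours are a saturated chain carbon, 4,4-difluoropiperidin-1-yl in place of tert-butoxy gives a number 5.9 percentage points lower from compound 3 to compound 4 (within the scatter) in this assay, the first step read at this site. Exchanging a group with no ring for one holding a six-membered non-aromatic ring therefore does not separate these two compounds, and both remain at a low level of inhibition. No measured property is available to bear on this result.

Still open, from the compounds shown here alone, is whether a carboxylic acid, a simple amine or a longer chain on this carbonyl carbon would give a number beyond the scatter of these two. For the compounds shown here, compound 1 and compound 2 differ from this pair in several places at once, so no single step shows which of those places goes with their higher numbers.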